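Swapping Trifluoromethyl for Methoxy on Two Related Cores

The source may hold more compounds than are shown below. What is called first, only, known or untested is meant among the compounds shown, and "the series" means these compounds.

Of the compounds shown here, three have been measured in a functional assay on OVCAR-3 cells (Homo sapiens) for inhibition, read by sulforhodamine B assay, with a stated time of 48 h; a lower number here means a stronger inhibitor of growth, a higher number a weaker inhibitor of growth. Compound 1 `O=C1C=COC(/C=C/c2ccc(C(F)(F)F)cc2)C1` gives 58.2 uM in this assay. Compound 2 `COc1ccc(/C=C/C2CC(=O)C=CO2)cc1` differs from compound 1 in a single place, (methoxy in place of trifluoromethyl on an aromatic carbon), and in this assay compound 2 gives 87.4 uM. Among the compounds with values here, the measured step of a 1.5-fold higher number from compound 1 to compound 2 (0.18 log units; within the scatter) is the only completed example of this change so far, and it is a small one.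

Compound 3 `O=C1C=CCC(/C=C/c2ccc(C(F)(F)F)cc2)N1` rests on a different core; how the two cores differ is not broken down here. In this assay compound 3 gives 126 uM. That number sits within the scatter of compound 2 but beyond the scatter of compound 1, so compound 3 is clearly a weaker growth inhibitor than compound 1, while nothing can be said about its order relative to compound 2.

Compound 4 `COc1ccc(/C=C/C2CC=CC(=O)N2)cc1` has not yet been measured. It differs from compound 3 by methoxy in place of trifluoromethyl on an aromatic carbon, which is the same change as that from compound 1 to compound 2, made at the same place on the aromatic ring. Within the data shown here, with only one earlier example to rest on, the expectation is that the change behaves much as it did before, and the step is expected to be a 1.5-fold higher number from compound 3 to compound 4 (0.18 log units; within the scatter), resting on the small measured step of a 1.5-fold higher number from compound 1 to compound 2 (0.18 log units; within the scatter) and on the value of compound 3. Compound 4 is therefore expected to give about 190 uM in this assay, with a range estimated from 100 uM to 350 uM.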

Compound 4, concentration for growth inhibition (reported as GI): 787 uM
Estimate against measurement, compound 4: 4.1-fold (0.62 log units) below, and the stated range ends below it.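

In this assay, putting methoxy in place of trifluoromethyl on the second core gives a 6.2-fold higher number from compound 3 to compound 4 (0.80 log units; beyond the scatter), so on this core the methoxy compound is clearly the weaker inhibitor of growth. The same change therefore does not carry from one core to the other at a single size, and the core on which it is made matters to what it does here: the same change on two cores in this assay, a 1.5-fold higher number (0.18 log units; within the scatter) from compound 1 to compound 2 and a 6.2-fold higher number (0.80 log units; beyond the scatter) from compound 3 to compound 4, 4.2-fold (0.62 log units) apart, beyond the scatter of two such steps

Within the data shown here, with only two pairs, this shows that the step differs between these two cores, but it does not show which feature of the cores accounts for the gap, and it offers no rule for any further core.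

The compounds shown carry only trifluoromethyl and methoxy at this place on the aromatic ring, so they leave open how a chlorine, a nitrile or a hydroxyl group there would behave on either core. They also leave open whether a longer chain such as ethoxy in place of methoxy would show the same gap between the cores.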